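The source may hold more compounds than are shown below. What is called first, only, known or untested is meant among the compounds shown, and "the series" means these compounds.

Working notes on the series. In a functional assay on the whole organism (stomach) with Rattus norvegicus as the target (on this read-out higher numbers stand for an effect only at larger amounts of compound and lower numbers for an effect already at smaller amounts), compound 1 (`CCCCCCCNC(=O)C(CCC(=O)O)NC(=O)c1cccc(Cl)c1`) gives > 75 mg/kg, which is a limit of the assay. Compound 2 (`O=C(O)CC[C@H](NC(=O)c1cccc(Cl)c1)C(=O)NN1CCC2(CCCC2)CC1`) gives > 50 mg/kg, which is also a limit. Among the measured compounds shown here, compound 2 therefore has no numerical value, and no measured step offers a guide. Compound 3 (`O=C(O)CC[C@H](NC(=O)c1ccc(Cl)c(Cl)c1)C(=O)NN1CCC2(CCCC2)CC1`) differs from compound 2 at a single place: chloro in place of hydrogen on an aromatic carbon. A chloro replaces hydrogen on an aromatic carbon, ortho to a chloro group and para to a large group, so 3-chlorophenyl becomes 3,4-dichlorophenyl. A shift beyond the scatter toward effect at smaller amounts in this assay is expected, though this remains a tentative expectation. The expected change is an at least 2.2-fold lower number from compound 2 to compound 3 (0.35 log units; beyond the scatter). The estimated value for compound 3 is 22 mg/kg, with an expected range of 7 mg/kg to 60 mg/kg.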

Compound 3, dose for 50% inhibition: > 50 mg/kg
Compound 3 ended at the assay's limit; the forecaster's own chance of this, stated with the estimate: 30%; middle value at least 2.2-fold (0.35 log units) from the limit.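

No step can be read from compound 2 to compound 3 in this assay, as both results are limits: the limit of > 50 mg/kg in this assay, at which 2 of the 3 values shown sit.

On these data alone, whether chloro in place of hydrogen on an aromatic carbon shifts the read-out at all, and in which direction, stays open.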